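The source may report more compounds than this note shows. Statements on the series, on what has been measured and on what is new or still open speak of the compounds shown alone.

Working notes, values from a functional assay on HT-29 cells (Homo sapiens) for cytotoxicity, read by MTT assay (a higher number here means a weaker inhibitor, a lower number a stronger inhibitor), as follows:

- compound 1 `COc1ccc(OC)c(C(=O)/C=C/c2occc2Br)c1` gives 15200 nM
- compound 2 `COc1ccc(OC)c(C(=O)/C=C/c2ccc(OC/C=C/c3ccccc3)cc2)c1` gives 26300 nM
- compound 3 `COc1ccc(OC)c(C(=O)/C=C/c2ccc(OC(=O)/C=C/c3ccc(C)cc3)cc2)c1` gives 16400 nM

In this assay compound 3 (at 16400 nM) sits within the usual scatter of both compound 1 and compound 2, so it cannot be ranked against either. For the measured compounds named here, no two measured compounds differ in one place only, so the series offers no measured step for judging a single change.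

Compound 4 `COc1ccc(/C=C/C(=O)Oc2ccc(/C=C/C(=O)c3cc(OC)ccc3OC)cc2)cc1` is still to be measured. It differs from compound 3 in one place: methoxy in place of methyl on an aromatic carbon, para to a large group (methoxy in place of methyl on an aromatic carbon).

No shift beyond the scatter is expected. Compound 1 (15200 nM) and compound 2 (26300 nM) differ from compound 3 by far more structure, yet their values stay within the scatter of its value. The estimated step of a 1.0-fold lower number from compound 3 to compound 4 (0.01 log units; within the scatter) is therefore small, with no firm direction. Compound 4 is expected at 16000 nM (estimated range 7000 nM to 35000 nM) in this series.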

Compound 4, half-maximal inhibitory concentration: 23000 nM
Estimate against measurement, compound 4: 1.4-fold (0.16 log units) below; the measured number falls inside the stated range.
By their numbers in this assay, from the lowest: compounds 1, 3, 4 and 2 (each within the scatter of the next).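

In this assay the series now has its first single-place comparison, and the change from 4-methylphenyl to 4-methoxyphenyl gives a 1.4-fold higher number from compound 3 to compound 4 (0.15 log units; within the scatter). At this aromatic carbon, para to a large group, the exchange of methyl for methoxy adds one heavy atom and one hydrogen-bond acceptor, yet compound 3 and compound 4 cannot be told apart. No accompanying measurement bears on this result.

This single pair leaves open whether methoxy in place of methyl would read the same on another aromatic carbon of the shared core. It also leaves open whether an amine, a carboxylic acid or a longer chain such as butoxy at this position would give a step beyond the scatter.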